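The source may hold more compounds than are shown below. What is called first, only, known or untested is meant among the compounds shown, and "the series" means these compounds.

Three ureas on a shared core have been run in a functional assay on HepG2 cells (Homo sapiens) for cytotoxicity, read by MTT assay, with a stated time of 72 h; a lower number here means a stronger inhibitor, a higher number a weaker inhibitor. Compound 1 `O=C(Nc1ccc(-n2ncc3c(C(F)(F)F)cccc32)cc1)Nc1ccc(Cl)c(C(F)(F)F)c1` gives 8000 nM, compound 2 `O=C(Nc1ccc(-n2ncc3c(Cl)cccc32)cc1)Nc1ccc(Cl)c(C(F)(F)F)c1` gives 1900 nM, and compound 3 `Cc1cccc2c1cnn2-c1ccc(NC(=O)Nc2ccc(Cl)c(C(F)(F)F)c2)cc1` gives 4000 nM. Compound 2 stands lowest of the three: a 4.2-fold lower number from compound 1 to compound 2 (0.62 log units; beyond the scatter) and a 2.1-fold higher number from compound 2 to compound 3 (0.32 log units; beyond the scatter) both lie beyond the scatter, whereas a 2.0-fold lower number from compound 1 to compound 3 (0.30 log units; within the scatter) does not. Compound 4 `COc1cccc2c1cnn2-c1ccc(NC(=O)Nc2ccc(Cl)c(C(F)(F)F)c2)cc1` differs from compound 2 by methoxy in place of chloro on an aromatic carbon. Among the compounds with values here, no methoxy analogue has been measured on this core. Within the data shown here, the only step that bears on the change is a 2.1-fold higher number from compound 2 to compound 3 (0.32 log units; beyond the scatter), a modest rise when chloro gave way to another group at the same aromatic carbon. The expected step is a 2.1-fold higher number from compound 2 to compound 4 (0.32 log units; beyond the scatter), a modest rise in the same direction. Compound 4 is therefore estimated at 4000 nM, within 1500 nM to 10000 nM.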

Compound 4, half-maximal inhibitory concentration: 4000 nM
For compound 4 middle estimate and measured number coincide at the digits printed; the measured number falls inside the stated range.
By their numbers in this assay, from the lowest: compound 2; then compounds 3, 4 and 1 (each within the scatter of the next).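

Methoxy at this aromatic carbon does not match chloro: a 2.1-fold higher number from compound 2 to compound 4 (0.32 log units; beyond the scatter) is a modest step, while no change at the digits printed from compound 3 to compound 4 (within the scatter) and a 2.0-fold lower number from compound 1 to compound 4 (0.30 log units; within the scatter) leave methoxy unseparated from methyl and trifluoromethyl. Within the data shown here, with a third comparison now in hand, compound 2 stands apart from compounds 1, 3 and 4, and chloro is the only one of these four groups to do so. Nothing measured here speaks to why chloro stands apart. Going by these compounds, whether fluoro, an amine or a carboxylic acid at this carbon would fall with chloro or with the other three remains open.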